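From thiophen-3-yl to 2,5-dimethylthiophen-3-yl: working notes

This account rests on a few compounds, and the source may have more. Where it says the series, first, only, none or still open, it means among the compounds named here.

Measured in a functional assay on cells (Cancer cell lines, Homo sapiens) for inhibition (a lower number here means a stronger inhibitor of growth, a higher number a weaker inhibitor of growth), as follows:
- compound 1 (`Cc1cc(-c2nc3sc(C)cn3c2/C=N/NC(=N)N)c(C)s1`): 9770 nM
- compound 2 (`N=C(N)N/N=C/c1c(-c2ccsc2)nc2sccn12`): 15100 nM

Compound 2 stands within the scatter of compound 1, so these two numbers give no order. Compound 3 (`Cc1cc(-c2nc3sccn3c2/C=N/NC(=N)N)c(C)s1`) differs from compound 2 in one place: 2,5-dimethylthiophen-3-yl in place of thiophen-3-yl on an aromatic carbon. For the measured compounds named here, no measured pair isolates this change. Compound 1 also carries 2,5-dimethylthiophen-3-yl and gives 9770 nM in this assay, within the scatter of compound 2, so no step beyond the scatter is expected. The estimated change is a 1.3-fold lower number from compound 2 to compound 3 (0.10 log units; within the scatter) and is expected to stay within the scatter. Compound 3 is expected at 12000 nM (estimated range 6000 nM to 24000 nM).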

Compound 3, concentration for 50% growth inhibition: 16600 nM
Compound 3: middle estimate off by 1.4-fold (0.14 log units), on the low side; measured number inside the range.
By their numbers in this assay, from the lowest: compounds 1, 2 and 3 (each within the scatter of the next).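

In this assay, the change from thiophen-3-yl to 2,5-dimethylthiophen-3-yl on this aromatic carbon can now be read directly: the step is a 1.1-fold higher number from compound 2 to compound 3 (0.04 log units; within the scatter) and gives no order between the two compounds. The new compound also isolates a second change, hydrogen in place of methyl on an aromatic carbon, and that step, a 1.7-fold higher number from compound 1 to compound 3 (0.23 log units; within the scatter), likewise gives no order, so neither change separates the compounds in this series. Nothing available here offers an explanation for either result.

The compounds shown cover only thiophen-3-yl, 2,5-dimethylthiophen-3-yl and the hydrogen and methyl exchange, so they leave open whether any change at these places can move the number beyond the scatter. An amine, a carboxylic acid or a longer alkyl chain at either place remains an open question.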